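This account rests on a few compounds, and the source may have more. Where it says the series, first, only, none or still open, it means among the compounds named here.

Measured compounds:
compound 1, `CCc1nc2c3ccccc3oc2c2c1c(=O)oc1cc(C)ccc12` — 41.7%
compound 2, `Cc1nc2c3ccccc3oc2c2c1c(=O)oc1cc(Cl)ccc12` — 25.9%

In a functional assay on the whole organism with Rattus norvegicus as the target, with a stated time of 3 h, at a dose of 300 mg/kg (a lower number here means a weaker effect, a higher number a stronger effect of the compound at the dose given), compound 1 gives 41.7%, the highest of the two numbers recorded. Compound 2 gives 25.9%, and its distance from compound 1 lies beyond the scatter of repeated measurements. Among the compounds with values here, the two compounds differ from each other in more than one place, so no single step can be read off between them, and no step between measured compounds that differ in one place exists in this set.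

Compound 3, `CCc1nc2c3ccccc3oc2c2c1c(=O)oc1cc(OC)ccc12`, has not yet been measured in this assay. It differs from compound 1 as follows: methoxy in place of methyl on an aromatic carbon. Within the data shown here, since no measured step covers this change, the expectation rests on compound 1 alone. A step of the size a number 3.7 percentage points lower from compound 1 to compound 3 (within the scatter) is expected, small enough to fall within the scatter and with no clear direction. Compound 3 is estimated at 38%, in a range from 20% to 56%.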

Compound 3, a percentage reported as inhibition, in the whole organism at one dose (the size of the read-out at that dose, not a potency): 78.1%
Compound 3: middle estimate off by 40.1 percentage points, on the low side, and the stated range ends below it.
By their numbers in this assay, from the lowest: compound 2; then compound 1; then compound 3.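

In this assay, within the data shown here, methoxy in place of methyl on an aromatic carbon gives a number 36.4 percentage points higher from compound 1 to compound 3 (beyond the scatter) and is the only change in this set that can be read at a single place. It shows that the read-out at this dose is sensitive to the group on this carbon of the six-membered aromatic ring of carbon only, even though the exchange adds just one oxygen and one hydrogen-bond acceptor to the core of compound 1. No measurement of any property bears on this step, and the reason for its size stays unknown.

As far as these compounds go, whether ethoxy, a hydroxyl or an amine on the same carbon would give a read-out like that of compound 3 remains open. From the compounds shown here alone, it is also open whether methoxy would give a step of this size with another group in place of the ethyl chain of compound 3.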